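The compounds below may be only part of what the source reports. "The series", "measured", "known", "first", "only" and "open" are said of these compounds alone.

Measured compounds: compound 1, `CCCCCCCCS(=O)(=O)Nc1ccc(-c2cccc(F)c2)cc1C(=O)O`, with 37600 nM; compound 2, `CCCCCCCCS(=O)(=O)Nc1ccc(C(=O)c2ccccc2OC)cc1C(=O)O`, with 59200 nM.

Both values come from an assay on mitochondria (strain BALB/c) for inhibition of glycerol-3-phosphate acyltransferase 1, mitochondrial (Mus musculus), read by scintillation counting, with a stated time of 10 min; on this read-out higher numbers stand for weaker inhibition and lower numbers for stronger inhibition. Compound 2 has the higher of the two numbers, but the gap to compound 1 is small: a 1.6-fold higher number from compound 1 to compound 2 (0.20 log units; within the scatter). Within this pair, then, the group on the aromatic carbon has made no difference that can be told apart from repeat-to-repeat noise.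

Compound 3, `CCCCCCCCS(=O)(=O)Nc1ccc(CCc2ccccc2)cc1C(=O)O`, has not yet been measured. It differs from compound 2 in one place: phenethyl in place of (2-methoxyphenyl)carbonyl on an aromatic carbon. For the measured compounds named here, the only step that speaks to this position is the one from compound 1 to compound 2, which stayed inside the scatter; there is no measured example of a group without a carbonyl or a methoxy at this position, so the evidence is thin. On that basis no step beyond the scatter is expected in this assay, with the uncertainty widened to allow for the new group. Compound 3 is therefore expected at about 45000 nM, in a range from 15000 nM to 130000 nM, meaning an estimated step of a 1.3-fold lower number from compound 2 to compound 3 (0.12 log units; within the scatter).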

Compound 3, half-maximal inhibitory concentration: 37500 nM
Estimate against measurement, compound 3: 1.2-fold (0.08 log units) above, within the range that was stated.
By their numbers in this assay, from the lowest: compounds 3, 1 and 2 (each within the scatter of the next).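

Phenethyl carries no oxygen and has no hydrogen-bond acceptors, against the two counted in the (2-methoxyphenyl)carbonyl it replaces, yet in this assay the change gives a 1.6-fold lower number from compound 2 to compound 3 (0.20 log units; within the scatter). This position now has an example without a carbonyl or a methoxy, and the number stays within the scatter, so neither of those features is required to keep inhibition at this level in this small set. Set against the 3-fluorophenyl group, phenethyl gives a 1.0-fold lower number from compound 1 to compound 3 (0.00 log units; within the scatter), which leaves three differently built groups, each with one six-membered aromatic ring, that cannot be told apart in this assay; nothing available explains why they read alike.

All three groups contain such a ring, so the compounds shown cannot say what would happen with a group lacking one, such as a small methyl or a plain hydrogen, or with an amine or a carboxylic acid placed on the ring. They also leave open whether any change at this position can move the number beyond the scatter at all, or whether a shorter chain in place of the octyl chain would matter more.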